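From Formyl to Methoxycarbonyl on the Shared Core

The compounds below may be only part of what the source reports. "The series", "measured", "known", "first", "only" and "open" are said of these compounds alone.

In a functional assay on NCI-H460 cells (Homo sapiens) (on this read-out lower numbers stand for an effect already at smaller amounts and higher numbers for an effect only at larger amounts of compound), compound 1 `CC(=O)N1N=C(c2ccc(N(C)C)cc2)OC1c1cc(C)c(C)c(C)c1` gives 5.7 uM and compound 2 `COc1cc(C2OC(c3ccc(N(C)C)cc3)=NN2C(C)=O)cc(OC)c1OC(C)=O` gives 13 uM. Compound 3 `COc1cc(C2OC(c3ccc(N(C)C)cc3)=NN2C=O)cc(OC)c1OC` gives 0.12 uM, the lowest of the three numbers and beyond the scatter from both others. Compound 4 `COC(=O)N1N=C(c2ccc(N(C)C)cc2)OC1c1cc(OC)c(OC)c(OC)c1` remains unmeasured and differs from compound 3 by methoxy in place of hydrogen on a carbonyl carbon. Going by the values given here, no measured pair isolates this change. Compound 1, with methyl on that carbonyl carbon but also another difference, stands at 5.7 uM, so a step to a higher number, beyond the scatter, is expected in this assay. The estimate implies an expected 8.3-fold higher number from compound 3 to compound 4 (0.92 log units; beyond the scatter). For compound 4 the estimated value is 1 uM, with an expected range of 0.2 uM to 6 uM.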

Compound 4, concentration for half-maximal effect: 106 uM
For compound 4 the middle estimate is 110-fold (2.03 log units) below the measured one, and the stated range ends below it.
By their numbers in this assay, from the lowest: compound 3; then compound 1; then compound 2; then compound 4.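

In this assay the carbonyl carbon on the amide-type nitrogen in a ring proves highly sensitive to what it carries: methoxy in place of hydrogen gives an 880-fold higher number from compound 3 to compound 4 (2.95 log units; beyond the scatter) with the rest of the shared core unchanged. Going by these compounds alone, this pair is the first to isolate a change at this place, and the step is large and beyond the scatter. Nothing available explains the size of this step.

The compounds shown leave open how an amine or an ethoxy group on that carbonyl carbon would read. They also leave open whether methyl there, on the otherwise unchanged core of compound 3, would stay close to formyl or move towards methoxycarbonyl.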